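Trifluoromethyl for methyl: what to expect of compound 4

The source may report more compounds than this note shows. Statements on the series, on what has been measured and on what is new or still open speak of the compounds shown alone.

Of the compounds shown here, three sharing one core have been tested in a functional assay on SW1573 cells (Homo sapiens) for inhibition, read by sulforhodamine B assay, with a stated time of 48 h; a higher number here means a weaker inhibitor of growth, a lower number a stronger inhibitor of growth. Compound 1 `COC(=O)[C@@]1(C)CCC=C2[C@@H]1CC[C@@H](C)[C@]2(C)Cc1c[nH]c2ccc(C)cc12` gives 15000 nM. Compound 2 `COC(=O)[C@@]1(C)CCC=C2[C@@H]1CC[C@@H](C)[C@]2(C)Cc1c[nH]c2c(C)cccc12` gives 7800 nM. Compound 3 `COC(=O)[C@@]1(C)CCC=C2[C@@H]1CC[C@@H](C)[C@]2(C)Cc1c(C)[nH]c2ccc(C)cc12` gives 18000 nM.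

Compound 3 has the highest of the three numbers. Its nearest neighbour is compound 1: the step of a 1.2-fold higher number from compound 1 to compound 3 (0.08 log units; within the scatter) is within the scatter, so the two cannot be told apart. Going by the values given here, the gap between compound 2 and compound 3 is beyond the scatter, and no single-point step links those two.

Compound 4 `COC(=O)[C@@]1(C)CCC=C2[C@@H]1CC[C@@H](C)[C@]2(C)Cc1c(C)[nH]c2ccc(C(F)(F)F)cc12` differs from compound 3 in one place: trifluoromethyl in place of methyl on an aromatic carbon. Among the compounds with values here, no measured step touches this position or this group; the only measured step, a 1.2-fold higher number from compound 1 to compound 3 (0.08 log units; within the scatter), adds a methyl on a different aromatic carbon and changes almost nothing. Nothing here shows how trifluoromethyl compares with methyl, so the expectation is a step of no clear direction, with wide uncertainty. The expected step of a 1.2-fold lower number from compound 3 to compound 4 (0.08 log units; within the scatter) is estimated to stay within the scatter. Compound 4 is therefore expected to give about 15000 nM in this assay, with a likely range from 5000 nM to 45000 nM.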

Compound 4, concentration for 50% growth inhibition: 15000 nM
Estimate against measurement, compound 4: no gap at the digits printed; the measured number falls inside the stated range.
By their numbers in this assay, from the lowest: compounds 2, 1, 4 and 3 (each within the scatter of the next, the first and the last beyond it).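

The step of a 1.2-fold lower number from compound 3 to compound 4 (0.08 log units; within the scatter) is the only measured change at this aromatic carbon among the compounds shown, and in this assay it leaves compound 3 and compound 4 impossible to tell apart. The earlier compounds shown here showed only that adding a methyl on a different aromatic carbon changes little; this result adds that, at this second place, methyl with its one heavy atom and trifluoromethyl with its four give readings that cannot be separated. The data on hand offer no measurement that would explain why the two groups read alike here.

Still open, going by these compounds, is whether a group of another kind on this same carbon, such as an amine, a carboxylic acid or a longer chain, would move the number beyond the usual scatter, and in which direction. Also open, on these data alone, is whether trifluoromethyl would read the same way on the core of compound 1, which has a hydrogen in place of the methyl that compound 3 and compound 4 both carry on the other aromatic carbon.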